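A few compounds are considered here, and "the series" means these few. Any claim that something is new, unique, unknown or untested is made for them only; others in the source may bear on it.

Compound 1 `COc1ccc(C2CC3(N(C)C)CC(=O)C2C(c2ccc(OC)cc2)C3)cc1` and compound 2 `COc1ccc(C2CC3(N4CCCC4)CC(=O)C2C(c2ccc(OC)cc2)C3)cc1` share one core. In an ADME assay on L6 cells (Rattus norvegicus) for cytotoxicity (a higher number here means a weaker inhibitor, a lower number a stronger inhibitor), compound 1 gives 52400 nM, and compound 2 gives 41900 nM. The change between them, (pyrrolidin-1-yl in place of dimethylamino on a saturated ring carbon), made a 1.3-fold lower number from compound 1 to compound 2 (0.10 log units; within the scatter). Compound 3 `CN(C)C12C/C(=N\O)C(C(c3ccccc3)C1)C(c1ccccc1)C2` is built on a different core, and the difference between the two cores is not broken down here. In this assay compound 3 gives 150000 nM, the highest of the three numbers. Compound 4 `O/N=C1\CC2(N3CCCC3)CC(c3ccccc3)C1C(c1ccccc1)C2` has not yet been measured. It differs from compound 3 by pyrrolidin-1-yl in place of dimethylamino on a saturated ring carbon. This is the same kind of change as from compound 1 to compound 2, though here the place is two ring bonds from the ring atom that bears a phenyl group rather than a 4-methoxyphenyl group. Compound 4 is expected to show a 1.2-fold lower number from compound 3 to compound 4 (0.06 log units; within the scatter), because the earlier step was a 1.3-fold lower number from compound 1 to compound 2 (0.10 log units; within the scatter). Compound 4 is therefore estimated at 130000 nM, with a range from 60000 nM to 300000 nM.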

Compound 4, half-maximal inhibitory concentration: 13500 nM
Beside the measured number, compound 4's estimate is 9.6-fold (0.98 log units) above it; measured number outside the range, below it.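

In this assay the replacement of dimethylamino by pyrrolidin-1-yl gave an 11-fold lower number from compound 3 to compound 4 (1.05 log units; beyond the scatter), and the size of this step did not carry over between the two cores: the same change on two cores in this assay, a 1.3-fold lower number (0.10 log units; within the scatter) from compound 1 to compound 2 and an 11-fold lower number (1.05 log units; beyond the scatter) from compound 3 to compound 4, 8.9-fold (0.95 log units) apart, beyond the scatter of two such steps. The step measured on the core of compound 1 therefore did not foretell the step on the core of compound 3. These two pairs do not show which difference between the cores goes with this gap, as the carbonyl of compound 1 and the oxime of compound 3 change together with 4-methoxyphenyl and phenyl.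

The compounds shown leave open whether an oxime combined with 4-methoxyphenyl groups would separate these two differences. They also leave open how a piperidin-1-yl or morpholin-4-yl group would behave on either core.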